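This account rests on a few compounds, and the source may have more. Where it says the series, first, only, none or still open, it means among the compounds named here.

Measured compounds:
Compound 1, `C/C(=N\O)c1ccc(NC(=O)CSc2nnc(-c3ccccc3)n2-c2ccccc2)cc1`, gives 66%
Compound 2, `COc1ccc(-c2nnc(SCC(=O)Nc3ccc(/C(C)=N/O)cc3)n2-c2ccccc2)cc1`, gives 58%

Of the compounds shown here, two sharing one core have been tested in a functional assay on the whole organism (strain albino) for inhibition, with Rattus norvegicus as the target, read by paw edema, with stated times of 30 min and 5 h, at a dose of 0.28 mmol/kg by the oral route; on this read-out higher numbers stand for more inhibition at the one dose given (going by the name of the read-out) and lower numbers for less inhibition. Compound 1 gives 66%, and compound 2 gives 58%. Going by the values given here, the one measured step, a number 8 percentage points lower from compound 1 to compound 2 (within the scatter), came with methoxy in place of hydrogen on an aromatic carbon and stays within the scatter. On the numbers shown compound 1 stands highest of the two, with compound 2 nearest, the gap between them being within the scatter.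

Compound 3, `CC(=O)c1ccc(NC(=O)CSc2nnc(-c3ccccc3)n2-c2ccccc2)cc1`, has not been measured in this assay. It differs from compound 1 in one place: a group of 3 heavy atoms (2 carbon, 1 oxygen; no ring) in place of a group of 4 heavy atoms (2 carbon, 1 nitrogen, 1 oxygen; no ring), on an aromatic carbon. The exchange sits on an aromatic carbon of a six-membered aromatic ring of carbon only, para to a large group, and puts acetyl in place of the group of 4 heavy atoms. Among the compounds with values here, no measured step touches this part of the structure; the single known step, a number 8 percentage points lower from compound 1 to compound 2 (within the scatter), concerns another part and was within the scatter. The step from compound 1 to compound 3 is therefore expected to be a number 4 percentage points lower from compound 1 to compound 3 (within the scatter), with nothing beyond the scatter anticipated. For compound 3 the estimate is 62%, ranging from 48% to 76%.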

Compound 3, a percentage reported as inhibition, in the whole organism at one dose (the size of the read-out at that dose, not a potency): 63%
Estimate against measurement, compound 3: 1 percentage points below; the measured number falls inside the stated range.
By their numbers in this assay, from the lowest: compounds 2, 3 and 1 (each within the scatter of the next).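

Going by these compounds alone, this is the first change at this position, on an aromatic carbon of a six-membered aromatic ring of carbon only, para to a large group, as the only earlier step concerned another part of the structure. In this assay the exchange of the group of 4 heavy atoms for acetyl gives a number 3 percentage points lower from compound 1 to compound 3 (within the scatter) and so does not separate the two compounds, even though the group that leaves counts 1 hydrogen-bond donor and acetyl counts 0 hydrogen-bond donors. For this one pair, at this one dose, the read-out therefore does not depend on keeping the group of 4 heavy atoms, and nothing measured here offers an explanation for that.

The compounds shown leave open whether an amine, a carboxylic acid or a longer chain on this aromatic carbon would move the inhibition of paw edema beyond the scatter, since both groups seen here give numbers within it. They also leave open whether acetyl would behave in the same way alongside the methoxy group of compound 2, and whether the two groups would still match at other doses.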